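The source may report more compounds than this note shows. Statements on the series, on what has been measured and on what is new or still open speak of the compounds shown alone.

Measured in an ADME assay on MDCK cells (Canis lupus familiaris) for cytotoxicity, read by microscopy, with a stated time of 48 h; on this read-out lower numbers stand for higher toxicity in this test and higher numbers for lower toxicity in this test:
- compound 1 `C[C@H]1[C@H](NCc2sccc2C2CCCCC2)C[C@H]2C[C@@H]1C2(C)C`: 1560 nM
- compound 2 `C=C(C)c1csc(CN[C@@H]2C[C@H]3C[C@@H]([C@H]2C)C3(C)C)c1`: 25000 nM
- compound 3 `C[C@H]1[C@H](NCc2cncnc2)C[C@H]2C[C@@H]1C2(C)C`: > 100000 nM

Compound 1 holds the lowest of the two numbers in this assay, and compound 2 sits well beyond the usual scatter above it. For compound 3 this assay reports only a limit, (the limit of > 100000 nM in this assay, at which 1 of the 3 values shown sits), not a number. Compound 4 `C[C@H]1[C@H](NCc2sccc2-c2ccccc2)C[C@H]2C[C@@H]1C2(C)C` is compound 1 with a single change: phenyl in place of cyclohexyl on an aromatic carbon. Within the data shown here, no measured pair separates these two groups, so the size of the step rests on the change alone. The group that leaves and the group that enters are both six-membered rings of carbon only. No step beyond the scatter is firmly expected in this assay, with a modest rise considered somewhat more likely than a fall. Compound 4 is therefore estimated at 3000 nM, between 1000 nM and 12000 nM, corresponding to an expected step of a 1.9-fold higher number from compound 1 to compound 4 (0.28 log units; within the scatter).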

Compound 4, minimum cytotoxic concentration: 12500 nM
Compound 4: the middle estimate sits 4.2-fold (0.62 log units) below what was measured; measured number above the stated range.
By their numbers in this assay, from the lowest: compound 1; then compounds 4 and 2 (each within the scatter of the next). At a limit, above all of these: compound 3.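

In this assay the group on this aromatic carbon, two ring bonds from the ring sulfur, matters even between two six-membered rings of carbon only: phenyl in place of cyclohexyl gives an 8.0-fold higher number from compound 1 to compound 4 (0.90 log units; beyond the scatter) with no change in heavy atoms, donors, acceptors or charge. Ring size alone therefore does not set the number at this position, since going from a non-aromatic to an aromatic ring is enough to move it beyond the usual scatter. Nothing measured here gives a cause for this step. Going by these compounds, whether an amine, a carboxylic acid or a pyridine ring on this same carbon would move the number further remains open.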